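Geometry of the exocyclic double bond in a thromboxane antagonist series

The source may hold more compounds than are shown below. What is called first, only, known or untested is meant among the compounds shown, and "the series" means these compounds.

Among three compounds measured in a functional assay on a cell-free system (plasma) for agonist activity at thromboxane A2 receptor (Homo sapiens) (a lower number here means a stronger inhibitor, a higher number a weaker inhibitor), compound 1 `O=C(O)COC/C=C1\C[C@H]2C[C@@H](O)[C@H](/C=N/NC(=O)Nc3ccc(Cl)c(Cl)c3)[C@H]2C1` gives 180 nM and holds the lowest number of the three. Compound 2 `O=C(O)CC/C=C1\C[C@H]2C[C@@H](O)[C@H](/C=N/NC(=O)Nc3cccc(Cl)c3)[C@H]2C1` gives 5200 nM in this assay, and compound 3 `O=C(O)COC/C=C1\C[C@H]2C[C@@H](O)[C@H](/C=N/NC(=O)Nc3ccccc3)[C@H]2C1` gives 6000 nM. Among the measured compounds shown here, the only single-point step among them concerns the aryl group on the semicarbazide nitrogen: a 33-fold higher number from compound 1 to compound 3 (1.52 log units; beyond the scatter). Compound 2 differs from compound 1 in two places, so its value alone shows that the two compounds stand well apart.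

Compound 4 `O=C(O)COC/C=C1/C[C@H]2C[C@@H](O)[C@H](/C=N/NC(=O)Nc3ccc(Cl)c(Cl)c3)[C@H]2C1` is the next compound under consideration. It differs from compound 1 in that (the two compounds have the same atoms and bonds and differ only in configuration as drawn: 1 of 6 stereo elements differ; a double bond is drawn E in compound 1 and Z in compound 4). For the measured compounds named here, no measured step touches the configuration of this double bond; the one available step concerns the aryl ring and bears on the present change only by showing that this scaffold responds strongly to a single alteration. A change in geometry of the side chain bearing the acid is therefore expected to move this assay beyond the scatter, most likely toward a higher number, giving an expected step of a 5.6-fold higher number from compound 1 to compound 4 (0.74 log units; beyond the scatter). Compound 4 is estimated at 1000 nM, with a range from 100 nM to 10000 nM.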

Compound 4, half-maximal inhibitory concentration: 60 nM
Compound 4: the middle estimate sits 17-fold (1.22 log units) above what was measured; the whole stated range lies above it.
By their numbers in this assay, from the lowest: compound 4; then compound 1; then compounds 2 and 3 (each within the scatter of the next).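

Among the compounds shown here, the earlier compounds showed only that the aryl group on the semicarbazide nitrogen moves the number in this assay; this result shows that the geometry of the double bond carrying the acid side chain moves it too, with the change from E to Z as drawn giving a 3.0-fold lower number from compound 1 to compound 4 (0.48 log units; beyond the scatter). The step is modest, but it lies beyond the scatter, so this double bond is not a neutral position on the shared core, and within this pair the Z form as drawn carries the lower number. The step can be assigned to that geometry alone, because nothing else separates the two structures: the fact that compounds 1 and 4 differ only in the configuration as drawn.

As far as these compounds go, this preference rests on a single pair, so it remains open whether the Z form would also give the lower number with the phenyl group of compound 3 or with the side chain and 3-chlorophenyl group of compound 2. The compounds shown also leave open how either geometry would behave with a longer chain ending in the carboxylic acid, or with a tetrazole in place of that acid.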